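Replacing 1-benzofuran-2-yl in compound 1: expectation for compound 3

This account rests on a few compounds, and the source may have more. Where it says the series, first, only, none or still open, it means among the compounds named here.

- compound 1 `Nc1ncnc2c1c(-c1cc3ccccc3o1)cn2[C@H]1CCN(C[C@@H]2CO2)C1` gives 4510 nM
- compound 2 `Nc1ncnc2c1c(-c1cc3ccccc3o1)cn2[C@H]1CCN(C[C@H]2CO2)C1` gives 4210 nM

Both values come from a functional assay on Daudi cells (Homo sapiens) for antiproliferative activity; on this read-out higher numbers stand for weaker inhibition and lower numbers for stronger inhibition. For the measured compounds named here, compound 1 stands level with compound 2, the only other measured compound. The step is a 1.1-fold lower number from compound 1 to compound 2 (0.03 log units; within the scatter), and it goes with the fact that compounds 1 and 2 differ only in the configuration as drawn.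

Compound 3 `Nc1ncnc2c1c(-c1cnc3[nH]ccc3c1)cn2[C@H]1CCN(C[C@@H]2CO2)C1` keeps the core and the side chain of compound 1 and changes one place: a group of 9 heavy atoms (7 carbon, 2 nitrogen; one five-membered aromatic ring with 1 hetero atom, one six-membered aromatic ring with 1 hetero atom) in place of a group of 9 heavy atoms (8 carbon, 1 oxygen; one five-membered aromatic ring with 1 hetero atom, one six-membered aromatic ring of carbon only), on an aromatic carbon. The step measured so far concerns a stereocentre at a saturated ring carbon, not the group on this aromatic carbon, so it gives no measure of the present change. Going by the values given here, no measured compound carries a replacement for the 1-benzofuran-2-yl group, and neither size nor direction can be read from the data.

The working expectation in this assay is therefore no step beyond the scatter, anchored on compound 1 at 4510 nM, with a wide margin. The expected change is a 1.1-fold higher number from compound 1 to compound 3 (0.04 log units; within the scatter). For compound 3 the estimated value is 5000 nM, with an expected range from 1000 nM to 25000 nM.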

Compound 3, half-maximal inhibitory concentration: 2990 nM
Estimate against measurement, compound 3: 1.7-fold (0.22 log units) above; the measured number falls inside the stated range.
By their numbers in this assay, from the lowest: compounds 3, 2 and 1 (each within the scatter of the next).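

Position notes: at the aromatic carbon two ring bonds from the ring atom bearing the 1-((oxiran-2-yl)methyl)pyrrolidin-3-yl group, the first reading of a replacement for 1-benzofuran-2-yl in this assay is a 1.5-fold lower number from compound 1 to compound 3 (0.18 log units; within the scatter). The exchange keeps the count of 9 heavy atoms and the one five-membered and one six-membered aromatic ring, but replaces the oxygen with nitrogen, places a hetero atom in the six-membered ring, and goes from 0 hydrogen-bond donors to 1; in this single pair, that set of differences goes with no step beyond the scatter, so this position accepts at least this one change without a readable loss or gain. Nothing available on the series bears on why this exchange gives this result.

On these data alone, it remains open whether a much smaller group at this position, such as methyl, or a group carrying an amine or a carboxylic acid, would give a step beyond the scatter. As far as these compounds go, it is also open whether the same exchange gives a comparable result on the side chain of compound 2, and which of the differences within the exchange, taken alone, would matter.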